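The source may report more compounds than this note shows. Statements on the series, on what has been measured and on what is new or still open speak of the compounds shown alone.

In a functional assay on MCF7 cells (Homo sapiens) for antiproliferative activity, read by sulforhodamine B assay, with a stated time of 48 h (on this read-out higher numbers stand for weaker inhibition and lower numbers for stronger inhibition), compound 2 `O=C1NCCN1c1ccc(S(=O)(=O)Nc2ccccc2)cc1` gives 470 nM, compound 1 `CCCCc1ccc(NS(=O)(=O)c2ccc(N3CCNC3=O)cc2)cc1` gives 770 nM and compound 3 `O=C1NCCN1c1ccc(S(=O)(=O)Nc2ccc(OC(F)F)cc2)cc1` gives 760 nM. Compound 2 is therefore not separated from the other two. Compound 4 `Cc1ccc(C)c(NS(=O)(=O)c2ccc(N3CCNC3=O)cc2)c1` differs from compound 2 by 2,5-dimethylphenyl in place of phenyl on a sulfonamide nitrogen, with 2,5-dimethylphenyl in place of phenyl on a sulfonamide nitrogen. Among the measured compounds shown here, no measured compound carries this group. The closest evidence is substitution on an aromatic carbon: a 1.6-fold lower number from compound 1 to compound 2 (0.21 log units; within the scatter) and a 1.6-fold higher number from compound 2 to compound 3 (0.21 log units; within the scatter), with a 1.0-fold lower number from compound 1 to compound 3 (0.01 log units; within the scatter) as the remaining comparison. All three lie within the scatter, so no step beyond the scatter is expected in this assay. The estimated step is a 1.3-fold higher number from compound 2 to compound 4 (0.11 log units; within the scatter). Compound 4 is expected at 600 nM, with an estimated range of 250 nM to 1400 nM.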

Compound 4, half-maximal inhibitory concentration: 48 nM
Estimate against measurement, compound 4: 13-fold (1.10 log units) above, and the stated range ends above it.
By their numbers in this assay, from the lowest: compound 4; then compounds 2, 3 and 1 (each within the scatter of the next).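

In this assay, 2,5-dimethylphenyl in place of phenyl on a sulfonamide nitrogen gives a 9.8-fold lower number from compound 2 to compound 4 (0.99 log units; beyond the scatter), the only step shown beyond the scatter. Compound 1, compound 2 and compound 3 lie within the scatter of each other, so this position had shown no sensitivity to substitution until compound 4. Nothing measured here accounts for the step.

As far as these compounds go, whether a single methyl on the phenyl ring carries the step remains open. So does the effect of a chlorine or an amine on that ring.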